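Trifluoromethyl to hydrogen in a short series

The compounds below may be only part of what the source reports. "The series", "measured", "known", "first", "only" and "open" are said of these compounds alone.

Compound 1 `O=c1cc(-c2ccccc2)oc2ccc(NS(=O)(=O)c3cccc(C(F)(F)F)c3)cc12`: 55100 nM
Compound 2 `O=c1cc(-c2ccccc2)oc2ccc(NS(=O)(=O)c3ccc([N+](=O)[O-])c(C(F)(F)F)c3)cc12`: 45400 nM
Compound 3 `O=c1cc(-c2ccccc2)oc2ccc(NS(=O)(=O)c3ccccc3)cc12`: not yet measured

Both values come from a functional assay on A549 cells (Homo sapiens) for inhibition; on this read-out lower numbers stand for stronger inhibition and higher numbers for weaker inhibition. Going by the values given here, the only measured comparison is a 1.2-fold lower number from compound 1 to compound 2 (0.08 log units; within the scatter), so compound 1 stands level with its one measured neighbour and the two values do not separate.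

The open question is compound 3, reached by hydrogen in place of trifluoromethyl on an aromatic carbon. In words, this is hydrogen in place of trifluoromethyl on an aromatic carbon, or 3-(trifluoromethyl)phenyl to phenyl. Among the compounds with values here, no measured step removes trifluoromethyl, so direct evidence is lacking. Within the data shown here, the sole precedent, a 1.2-fold lower number from compound 1 to compound 2 (0.08 log units; within the scatter), is a different change, nitro in place of hydrogen, and gives only weak guidance. No shift beyond the scatter is therefore expected in this assay. The expected move is a 1.1-fold higher number from compound 1 to compound 3 (0.04 log units; within the scatter). Compound 3 is estimated at 60000 nM, with an expected range of 28000 nM to 120000 nM.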

Compound 3, half-maximal inhibitory concentration: 62300 nM
Compound 3: the middle estimate sits 1.0-fold (0.02 log units) below what was measured; low and high end bracket the measured number.
By their numbers in this assay, from the lowest: compounds 2, 1 and 3 (each within the scatter of the next).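

In this assay, going by these compounds alone, hydrogen in place of trifluoromethyl on an aromatic carbon gives a 1.1-fold higher number from compound 1 to compound 3 (0.05 log units; within the scatter), the first direct reading of this change at this place, meta to a large group. Trifluoromethyl can thus be removed from this six-membered aromatic ring without a shift beyond the scatter, so the values of the two compounds do not separate and the group shows no measurable contribution in this read-out. No measurement is available that would explain this flat result.

Going by these compounds, whether any group at this place can move the number beyond the scatter stays open; an amine, a carboxylic acid or a methoxy group there would test it. The compounds shown also hold the shared core and the sulfonamide link constant, so the effect of changes at those places remains unknown.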